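The source may report more compounds than this note shows. Statements on the series, on what has been measured and on what is new or still open speak of the compounds shown alone.

Working notes on the series. Compound 1 `COC(=O)C1=C(C)NC(=O)NC1c1cccs1` gives 19% in an assay on membranes from HEK293 cells for displacement of a labelled ligand from adenosine receptor A2b (Homo sapiens), read by scintillation counting, with a stated time of 30 min, tested at 1 uM; a lower number here means less inhibition, a higher number more inhibition at the concentration tested (going by the name of the read-out). Within the data shown here, compound 2 `CC1=C(C(=O)NC(C)C)C(c2cccs2)NC(=O)N1` gives 40% in this assay, the higher of the two numbers measured so far; the only step in the set, a number 21 percentage points higher from compound 1 to compound 2 (beyond the scatter), came with isopropylamino in place of methoxy on a carbonyl carbon. Compound 3 `CC1=C(c2ncc(C)o2)C(c2cccs2)NC(=O)N1` differs from compound 2 as follows: 5-methyl-1,3-oxazol-2-yl in place of isopropylcarbamoyl on a double-bonded ring carbon. Among the measured compounds shown here, no measured step bears directly on this change: the one step known alters what sits on a carbonyl carbon and keeps the carbonyl, whereas here the whole isopropylcarbamoyl group leaves and a five-membered aromatic ring enters. The size of the step in this assay is therefore uncertain; a modest step downward is expected, a number 10 percentage points lower from compound 2 to compound 3 (within the scatter), with a wide margin either way. Compound 3 is estimated at 30%, between 5% and 60%.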

Compound 3, a percentage reported as inhibition, at one concentration (the size of the read-out at that concentration, not a potency): 45%
Estimate against measurement, compound 3: 15 percentage points below; low and high end bracket the measured number.
By their numbers in this assay, from the lowest: compound 1; then compounds 2 and 3 (each within the scatter of the next).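

At this double-bonded ring carbon, the carbonyl and the amide hydrogen of isopropylcarbamoyl can give way to a five-membered aromatic ring without a separation in this assay: a number 5 percentage points higher from compound 2 to compound 3 (within the scatter). Set against methoxycarbonyl, 5-methyl-1,3-oxazol-2-yl gives a number 26 percentage points higher from compound 1 to compound 3 (beyond the scatter), so among these compounds, two different groups of the same heavy-atom count both stand clear of methoxycarbonyl. No supporting data on these compounds bear on why the two groups read alike.

The compounds shown leave open whether the methyl group on the oxazole ring matters, and whether a carboxylic acid, a primary amide or a longer chain on the amide nitrogen would fit this position equally well. Single-concentration inhibition also leaves open how compound 2 and compound 3 compare in potency.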